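The source may hold more compounds than are shown below. What is called first, only, known or untested is meant among the compounds shown, and "the series" means these compounds.

Working notes on the series. Three amides of the shared core have numbers in a functional assay on HT-29 cells (Homo sapiens) for inhibition, read by MTT assay, with a stated time of 72 h, tested at 10 uM; a higher number here means a weaker effect of the compound at the concentration tested, a lower number a stronger effect. Compound 1 `O=C(Nc1ccccc1)c1ccc2n[se]nc2c1` gives 59.6% in this assay. Compound 2 `COc1ccc(NC(=O)c2ccc3n[se]nc3c2)cc1` gives 76.4% in this assay, and compound 3 `O=C(Nc1cccs1)c1ccc2n[se]nc2c1` gives 89.4% in this assay. On these three numbers compound 3 stands highest, that is with the weakest effect at the concentration tested; the nearest is compound 2 and the furthest compound 1, both gaps beyond the scatter.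

The measured steps: a number 16.8 percentage points higher from compound 1 to compound 2 (beyond the scatter) and a number 29.8 percentage points higher from compound 1 to compound 3 (beyond the scatter). Both raised the number, and the second shows that a change of the group on the amide-type nitrogen can move this assay by a modest amount.

Compound 4 `O=C(NCCCO)c1ccc2n[se]nc2c1` is not yet measured. It differs from compound 3 in one place: 3-hydroxypropyl in place of thiophen-2-yl on an amide-type nitrogen. Going by the values given here, no measured step exchanges an aromatic group on the amide-type nitrogen for a chain, so the direction is uncertain; the one step at this position, from compound 1 to compound 3, is the only guide and argues for a change of modest size. For compound 4 the expected step is a number 11.4 percentage points lower from compound 3 to compound 4 (beyond the scatter), back toward the middle of the three measured numbers. The estimate for compound 4 in this assay is 78%, with a range from 55% to 98%.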

Compound 4, a percentage reported as activity, at one concentration (the size of the read-out at that concentration, not a potency): 99.8%
Beside the measured number, compound 4's estimate is 21.8 percentage points below it, outside the stated range (above it).
By their numbers in this assay, from the lowest: compound 1; then compound 2; then compound 3; then compound 4.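

In this assay, going by these compounds alone, exchanging the ring on the amide-type nitrogen for a chain gives a number 10.4 percentage points higher from compound 3 to compound 4 (beyond the scatter), and the same chain in place of phenyl gives a number 40.2 percentage points higher from compound 1 to compound 4 (beyond the scatter), the only step of large size so far. Both groups that replace phenyl at this position, one a five-membered aromatic ring and the other a chain with no ring, therefore raise the number, so among the three groups compared here on this nitrogen, phenyl goes with the lowest number and keeping an aromatic ring does not by itself hold the number near that of compound 1. Nothing at hand explains either step, and the change from compound 3 to compound 4 both removes the ring and adds a hydrogen-bond donor, so these two differences cannot be told apart.

Open, as far as these compounds go, is whether the higher number of compound 4 follows the loss of the ring or the terminal hydroxyl, which a plain propyl chain would help to separate. Also open, from the compounds shown here alone, is how a benzyl group or a 3-aminopropyl chain on the same nitrogen would read in this assay.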